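A few compounds are considered here, and "the series" means these few. Any claim that something is new, unique, unknown or untested is made for them only; others in the source may bear on it.

Measured compounds:
Compound 1 `C[C@@H](O)[C@H]1C(=O)N2C(C(=O)OCOC(=O)C3CCCCC3)=C(S[C@@H]3CN[C@H](C(=O)Nc4cccc(C(=O)O)c4)C3)[C@H](C)[C@H]12`: in a physicochemical assay for metabolic stability, read by LC-MS, in phosphate buffer, with a stated time of 3 h, at pH 7.4, tested at 50 uM (on this read-out higher numbers stand for a more stable compound and lower numbers for a less stable compound), compound 1 gives > 95%, which is a limit of the assay rather than a number.
Compound 2 `CCC(CC)C(=O)OCOC(=O)C1=C(S[C@@H]2CN[C@H](C(=O)Nc3cccc(C(=O)O)c3)C2)[C@H](C)[C@@H]2[C@@H]([C@@H](C)O)C(=O)N12`: in this assay compound 2 gives > 95%, again a limit of the assay.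

Going by the values given here, compound 1 therefore stands only at a limit, and so does its one neighbour, since both values sit at the limit of > 95% in this assay, at which 2 of the 2 values shown sit. Among the compounds with values here, the single measured step, a step that the two limits leave unreadable from compound 1 to compound 2, cannot be read for size or direction, because the limit of > 95% in this assay, at which 2 of the 2 values shown sit, hides whatever difference the two compounds may have.

Compound 3 `C[C@@H](O)[C@H]1C(=O)N2C(C(=O)OCOC(=O)C3CCCCC3)=C(S[C@@H]3CN[C@H](C(=O)Nc4cccc(C(=O)OCOC(=O)C5CCCCC5)c4)C3)[C@H](C)[C@H]12` differs from compound 1 by ((cyclohexylcarbonyl)oxy)methyl in place of hydrogen on an oxygen next to a carbonyl group; put another way, a hydroxy becomes ((cyclohexylcarbonyl)oxy)methoxy. Within the data shown here, no measured step covers this kind of change, so the expectation rests only on where compound 1 stands. Compound 3 is expected to remain largely intact, at about 90% with a range from 70% to 98%. The expected step of a number at least 5 percentage points lower from compound 1 to compound 3 (that floor lies within the scatter) is thus one of little or no size beyond the scatter, though a limit value may again be all that is reported.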

Compound 3, percent of the compound remaining: > 95%
Compound 3 ended at the assay's limit (the forecaster's own chance of this, stated with the estimate: 55%); middle value at least 5 percentage points from the limit.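

No step can be read between compound 1 and compound 3, since both stand at a limit of this assay rather than at a number: the limit of > 95% in this assay, at which 3 of the 3 values shown sit. Going by these compounds, whether compound 1, compound 2 and compound 3 differ at all in stability, and by how much, stays open.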